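The source may report more compounds than this note shows. Statements on the series, on what has been measured and on what is new or still open speak of the compounds shown alone.

Compound 1 `O=C(CCc1cccc2c1B(O)OC2)Nc1ccccc1` is the starting point; in a functional assay on MDA-MB-231 cells (Homo sapiens) for antiproliferative activity, read by MTT assay, with a stated time of 72 h (on this read-out higher numbers stand for weaker inhibition and lower numbers for stronger inhibition), compound 1 gives 230 nM. Compound 2 `COc1ccccc1NC(=O)CCc1cccc2c1B(O)OC2` carries methoxy in place of hydrogen on an aromatic carbon and in this assay compound 2 gives 930 nM. Compound 3 `COc1cccc(-c2cccc(NC(=O)CCc3ccc4c(c3)B(O)OC4)c2)c1` is built on a different core; the difference between the two cores is not broken down here. In this assay compound 3 gives 49000 nM. Compound 4 `COc1cc(OC)cc(-c2cccc(NC(=O)CCc3ccc4c(c3)B(O)OC4)c2)c1` differs from compound 3 by methoxy in place of hydrogen on an aromatic carbon. Going by the values given here, this is the same kind of change as the one between compound 1 and compound 2, though not the same: there the incoming methoxy sat ortho to a large group, here it sits meta to a large group and meta to a methoxy group. Because the earlier step of a 4.0-fold higher number from compound 1 to compound 2 (0.61 log units; beyond the scatter) went toward weaker inhibition, compound 4 is expected to show a 1.6-fold higher number from compound 3 to compound 4 (0.21 log units; within the scatter), a step of roughly similar size. Compound 4 is therefore estimated at 80000 nM, most likely between 25000 nM and 250000 nM.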

Compound 4, half-maximal inhibitory concentration: 21000 nM
The estimate for compound 4 lay 3.8-fold (0.58 log units) above the measured number; the whole stated range lies above it.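

Adding a second methoxy group to the 3-methoxyphenyl ring gives, in this assay, a 2.3-fold lower number from compound 3 to compound 4 (0.37 log units; beyond the scatter), which is the opposite direction from the earlier methoxy step. The same change therefore did not carry over from one core to the other, in either direction or size: the same change on two cores in this assay, a 4.0-fold higher number (0.61 log units; beyond the scatter) from compound 1 to compound 2 and a 2.3-fold lower number (0.37 log units; beyond the scatter) from compound 3 to compound 4, 9.4-fold (0.97 log units) apart, beyond the scatter of two such steps

Going by these compounds alone, with only one pair on each core, and the incoming methoxy in a different place in each pair, this does not show whether the core or the place of the group sets the direction. The compounds shown leave open whether a different group on the 3-methoxyphenyl ring, such as an amine or a carboxylic acid, would move the number the same way as the second methoxy.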